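Adding Fluoro to Compound 3: A Small Step Expected

The compounds below may be only part of what the source reports. "The series", "measured", "known", "first", "only" and "open" are said of these compounds alone.

Measured in a functional assay on A549 cells (Homo sapiens) for antiproliferative activity, read by MTT assay, with a stated time of 72 h; on this read-out lower numbers stand for stronger inhibition and higher numbers for weaker inhibition:
Compound 1, `COc1cccc(-c2ccc3ncn(-c4cc(OC)c(OC)c(OC)c4)c3c2)c1`, gives 3180 nM.
Compound 2, `COc1ccccc1-c1ccc2ncn(-c3cc(OC)c(OC)c(OC)c3)c2c1`, gives 4320 nM.
Compound 3, `COc1cc(-n2cnc3ccc(-c4ccccc4)cc32)cc(OC)c1OC`, gives 3060 nM.

Compound 3 has the lowest of the three numbers, yet the steps of a 1.0-fold lower number from compound 1 to compound 3 (0.02 log units; within the scatter) and a 1.4-fold lower number from compound 2 to compound 3 (0.15 log units; within the scatter) both sit within the scatter, as does a 1.4-fold higher number from compound 1 to compound 2 (0.13 log units; within the scatter), so none of the three can be called stronger than another. Compound 4, `COc1cc(-n2cnc3ccc(-c4ccc(F)cc4)cc32)cc(OC)c1OC`, differs from compound 3 by fluoro in place of hydrogen on an aromatic carbon. Going by the values given here, no measured step adds or removes a fluoro; the steps at hand concern methoxy only and all stay within the scatter. On that footing the step for compound 4 is expected to be a 1.0-fold lower number from compound 3 to compound 4 (0.01 log units; within the scatter), no change beyond the scatter. Compound 4 is therefore estimated at 3000 nM, in the range 1500 nM to 6000 nM.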

Compound 4, half-maximal inhibitory concentration: 6740 nM
Estimate against measurement, compound 4: 2.2-fold (0.35 log units) below, outside the stated range (above it).
By their numbers in this assay, from the lowest: compounds 3, 1, 2 and 4 (each within the scatter of the next, the first and the last beyond it).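

In this assay, going by these compounds alone, going from phenyl to 4-fluorophenyl is the first single change here to pass the scatter, with a 2.2-fold higher number from compound 3 to compound 4 (0.34 log units; beyond the scatter) as its result. Against the methoxy compounds the picture is split, since a 2.1-fold higher number from compound 1 to compound 4 (0.33 log units; beyond the scatter) lies beyond the scatter while a 1.6-fold higher number from compound 2 to compound 4 (0.19 log units; within the scatter) stays within it. Nothing measured here gives a reason for this step.

The compounds shown leave open whether the step belongs to fluoro alone or would also appear with chloro, an amine or a carboxylic acid in the same place.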